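Swapping an acid-bearing chain for a chloropyridine ring

This account rests on a few compounds, and the source may have more. Where it says the series, first, only, none or still open, it means among the compounds named here.

Of the compounds shown here, three sharing one core have been measured in an ADME assay for permeability, using PAMPA; a higher number here means that the compound crosses the layer faster, a lower number that the compound crosses the layer more slowly. Compound 1 `C=CC(=O)Nc1cccc(-c2nc3ccccc3s2)c1` gives 797 10^-6 cm/s, and compound 2 `C=C(C)C(=O)Nc1cccc(-c2nc3ccccc3s2)c1` gives 987 10^-6 cm/s; the gap between them, a 1.2-fold higher number from compound 1 to compound 2 (0.09 log units; within the scatter), is nothing to build on. Compound 3 `O=C(O)/C=C/C(=O)Nc1cccc(-c2nc3ccccc3s2)c1` stands lowest of the three, at 4 10^-6 cm/s, and the fall to it is large from both sides: a 200-fold lower number from compound 1 to compound 3 (2.30 log units; beyond the scatter), and a 250-fold lower number from compound 2 to compound 3 (2.39 log units; beyond the scatter).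

Compound 4 `O=C(Nc1cccc(-c2nc3ccccc3s2)c1)c1cnccc1Cl` has not been measured. It differs from compound 3 in one place: 4-chloropyridin-3-yl in place of 2-carboxyethenyl on a carbonyl carbon. The two steps that bear on this are the ones that brought the 2-carboxyethenyl group in, a 200-fold lower number from compound 1 to compound 3 (2.30 log units; beyond the scatter) and a 250-fold lower number from compound 2 to compound 3 (2.39 log units; beyond the scatter), both far beyond the scatter. Compound 4 removes that group and puts in an aromatic ring with no hydrogen-bond donor, so a large rise is expected, though compounds 1 and 2 carry vinyl and 1-methylethenyl rather than the incoming ring, so a full return to their level is not certain. For compound 4 the expected step in this assay is a 130-fold higher number from compound 3 to compound 4 (2.10 log units; beyond the scatter). The estimate for compound 4 is 500 10^-6 cm/s, within a range from 120 10^-6 cm/s to 1200 10^-6 cm/s.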

Compound 4, apparent permeability: 732 10^-6 cm/s
The estimate for compound 4 lay 1.5-fold (0.17 log units) below the measured number; measured number inside the range.
By their numbers in this assay, from the lowest: compound 3; then compounds 4, 1 and 2 (each within the scatter of the next).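

In this assay the step is a 180-fold higher number from compound 3 to compound 4 (2.26 log units; beyond the scatter) and it shows that the low number of compound 3 is not fixed by the shared core, since replacing the 2-carboxyethenyl group on the carbonyl carbon is enough to lift it. This position also accepts a six-membered aromatic ring, not only a short chain: the steps of a 1.1-fold lower number from compound 1 to compound 4 (0.04 log units; within the scatter) and a 1.3-fold lower number from compound 2 to compound 4 (0.13 log units; within the scatter) both lie within the scatter, so compound 4 cannot be told apart from compounds 1 and 2. Of the four groups shown here, three give numbers within the scatter of one another, and 2-carboxyethenyl alone goes against that.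

On these data alone, whether the fall in compound 3 follows the carboxylic acid itself or the chain that carries it stays open, as does how an amine at this place would behave. Nothing given here explains why the numbers fall as they do.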